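The compounds below may be only part of what the source reports. "The series", "measured", "known", "first", "only" and "open" are said of these compounds alone.

Compound 1 `C#CCN(Cc1ccc2nc(C)[nH]c(=O)c2c1)c1ccc(C(=O)N[C@@H](C[C@H](F)C(=O)O)C(=O)O)cc1` is one of three compounds whose numbers are known in a functional assay (B cell) with Homo sapiens as the target; a lower number here means a stronger inhibitor, a higher number a weaker inhibitor. Compound 1 gives 8.08 nM, level at the digits shown with compound 3 `Cc1nc2ccc(CN(C)c3ccc(C(=O)N[C@@H](C[C@@H](F)C(=O)O)C(=O)O)s3)cc2c(=O)[nH]1`, which gives 8.08 nM; the two lie within the usual scatter, so nothing separates them. Together they sit at the low end of the three numbers, far from compound 2 `Nc1nc2c(c(=O)[nH]1)C[C@@H](CCc1ccc(C(=O)N[C@@H](C[C@@H](F)C(=O)O)C(=O)O)cc1)CN2`, which gives 2930 nM. Among the compounds with values here, the gap between compound 1 and compound 2 is well beyond the scatter, but no single-change step links those two, so only the two values themselves can be read.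

Compound 4 `C#CCN(Cc1ccc2nc(C)[nH]c(=O)c2c1)c1ccc(C(=O)N[C@@H](C[C@@H](F)C(=O)O)C(=O)O)cc1` has not yet been measured. It differs from compound 1 as follows: the two compounds have the same atoms and bonds and differ only in configuration as drawn: 1 of 2 stereo elements differ; a stereocentre at a saturated chain carbon is drawn S in compound 1 and R in compound 4. Within the data shown here, no measured pair shows exactly this change. Compound 3 gives 8.08 nM with its stereocentre at a saturated chain carbon drawn in the same sense as in compound 4, which hints that this configuration is at least tolerated. Compound 4 is therefore expected to show a step of a 1.5-fold higher number from compound 1 to compound 4 (0.17 log units; within the scatter) that stays within the scatter or leans slightly weaker. Compound 4 is estimated at 12 nM, within 4 nM to 40 nM.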

Compound 4, half-maximal inhibitory concentration: 8.08 nM
Beside the measured number, compound 4's estimate is 1.5-fold (0.17 log units) above it; the range from low to high includes it.
By their numbers in this assay, from the lowest: compounds 1, 3 and 4 (each within the scatter of the next); then compound 2.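

In this assay, the switch of the stereocentre at a saturated chain carbon from S to R shows no change at the digits printed from compound 1 to compound 4 (within the scatter), so the two drawn senses cannot be told apart in this pair. Among the earlier compounds, no pair isolated this centre, and compound 2 and compound 3 each carried it in one sense only. Here the change can be read on its own, with nothing else in the structure altered: the fact that compounds 1 and 4 differ only in the configuration as drawn.

As far as these compounds go, whether a hydroxyl group or a plain hydrogen in place of the fluorine on the chain would read the same remains open. Also open is whether the centre would be equally undemanding in the setting of compound 2 or compound 3, where its other sense is not among the compounds shown.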